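Nitrophenyl regioisomer in a sulfonamide-bearing fused series

The source may hold more compounds than are shown below. What is called first, only, known or untested is meant among the compounds shown, and "the series" means these compounds.

Measured so far:
compound 1 `N#CC1=C(N)N(c2ccc(S(N)(=O)=O)cc2)C2=C(C(=O)CCC2)C1/C=C/c1ccccc1`: 2%
compound 2 `N#CC1=C(N)N(c2ccc(S(N)(=O)=O)cc2)C2=C(C(=O)CCC2)C1c1cccc([N+](=O)[O-])c1`: 42%

In a functional assay on Ehrlich cells (Mus musculus) for antiproliferative activity, read by trypan blue exclusion, with a stated time of 2 h, tested at 10 ug/mL (a higher number here means a stronger effect of the compound at the concentration tested, a lower number a weaker effect), compound 2 gives 42% and stands highest of the two numbers; compound 1 sits a number 40 percentage points higher from compound 1 to compound 2 (beyond the scatter) away. Compound 3 `N#CC1=C(N)N(c2ccc(S(N)(=O)=O)cc2)C2=C(C(=O)CCC2)C1c1ccc([N+](=O)[O-])cc1` differs from compound 2 only in this way: 4-nitrophenyl in place of 3-nitrophenyl on a saturated ring carbon. For the measured compounds named here, the one measured step, from compound 1 to compound 2, changes a different group and so does not bear on this move; no step within the nitrophenyl position is known. The step of a number 2 percentage points lower from compound 2 to compound 3 (within the scatter) is therefore expected to stay within the scatter, and compound 3 is estimated at 40% (15% to 65%).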

Compound 3, a percentage reported as activity, at one concentration (the size of the read-out at that concentration, not a potency): 85%
Estimate against measurement, compound 3: 45 percentage points below, outside the stated range (above it).
By their numbers in this assay, from the lowest: compound 1; then compound 2; then compound 3.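

In this assay, the saturated ring carbon proves sensitive not only to which group it carries but also to where the nitro group sits on the phenyl ring: the same atoms, joined differently, give a number 43 percentage points higher from compound 2 to compound 3 (beyond the scatter). With a number 83 percentage points higher from compound 1 to compound 3 (beyond the scatter) as well, the 4-nitrophenyl group gives the highest of the three values. No available data explain this difference.

Going by these compounds, whether 4-aminophenyl or 4-carboxyphenyl on this carbon would keep the effect remains open, as does the standing of 2-nitrophenyl. Each value comes from one concentration, so the comparison speaks only of a stronger or weaker effect at that concentration.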